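Flipping the ring stereocentre once more, now with cyclohexyl

The compounds below may be only part of what the source reports. "The series", "measured", "known", "first", "only" and "open" are said of these compounds alone.

Measured compounds:
compound 1 `Cc1ccccc1NC(=O)Nc1ccc(CNC(=O)C2=CCN(C(=O)CC(=O)O)[C@H]2C(C)C)cc1`, > 1000 nM (a limit of the assay)
compound 2 `Cc1ccccc1NC(=O)Nc1ccc(CNC(=O)C2=CCN(C(=O)CC(=O)O)[C@@H]2C(C)C)cc1`, 10 nM
compound 3 `Cc1ccccc1NC(=O)Nc1ccc(CNC(=O)C2=CCN(C(=O)CC(=O)O)[C@@H]2C2CCCCC2)cc1`, 62 nM

In an assay on Jurkat cells for inhibition of integrin alpha-4/beta-1 (Homo sapiens) (a higher number here means a weaker inhibitor, a lower number a stronger inhibitor), compound 1 gives only a limit, > 1000 nM. Compound 2 is the same molecule drawn with the opposite configuration at its single stereocentre, and in this assay compound 2 gives 10 nM; the step is an at least 100-fold lower number from compound 1 to compound 2 (2.00 log units; beyond the scatter). Compound 3 carries cyclohexyl in place of isopropyl on that saturated ring carbon and gives 62 nM, a step of a 6.2-fold higher number from compound 2 to compound 3 (0.79 log units; beyond the scatter); among the numbers shown it is the highest, with compound 2 the nearest value.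

Compound 4 `Cc1ccccc1NC(=O)Nc1ccc(CNC(=O)C2=CCN(C(=O)CC(=O)O)[C@H]2C2CCCCC2)cc1` has not been measured. Its difference from compound 3 is the two compounds have the same atoms and bonds and differ only in configuration as drawn: 1 of 1 stereo elements differ; a stereocentre at a saturated ring carbon is drawn R in compound 3 and S in compound 4. Among the measured compounds shown here, the only measured step of this kind is an at least 100-fold lower number from compound 1 to compound 2 (2.00 log units; beyond the scatter), which was large and went in the other direction as drawn. The same inversion applied to compound 3 is therefore expected to raise the number strongly in this assay, quite possibly past the reporting limit. Compound 4 is expected to give 6000 nM, within 1000 nM to 40000 nM. The expected step is a 97-fold higher number from compound 3 to compound 4 (1.99 log units; beyond the scatter).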

Compound 4, half-maximal inhibitory concentration: > 1000 nM
Compound 4 gave a limit, no number (the forecaster's own chance of this, stated with the estimate: 70%); the middle value does not contradict the limit.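

In this assay, the inversion gives an at least 16-fold higher number from compound 3 to compound 4 (1.20 log units; beyond the scatter), so the preference for one configuration at this saturated ring carbon is not confined to isopropyl: with cyclohexyl as well, the form drawn R gives the lower number, as in the pair of compound 1 and compound 2. Compound 4 gives > 1000 nM, which is a limit of the assay and not a number. Compound 1 also sits at a limit, so the step between the two forms drawn S cannot be read, and the effect of swapping isopropyl for cyclohexyl is visible only among the forms drawn R.

Going by these compounds, whether the same preference holds with a methyl group, a phenyl ring or an amine on this carbon remains open. The full size of the gap between the two configurations also remains unsettled in both pairs.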